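Chloro to Hydrogen: Expected Effect on Cytotoxicity

The source may report more compounds than this note shows. Statements on the series, on what has been measured and on what is new or still open speak of the compounds shown alone.

Three compounds have been measured in a functional assay on HL-60 cells (Homo sapiens) for cytotoxicity, read by MTT assay; on this read-out lower numbers stand for stronger inhibition and higher numbers for weaker inhibition:

compound 1 `Oc1ccc(O)c(COCc2cc(O)cc(Cl)c2O)c1` gives 6100 nM
compound 2 `Oc1ccc(O)c(COCc2cc(O)ccc2O)c1` gives 5500 nM
compound 3 `OCc1cc(OCc2cc(O)ccc2O)cc(Cl)c1O` gives 5300 nM

Compound 3 shows the lowest of the three numbers, but its separation from compound 2 and from compound 1 lies within the scatter, so the three compounds cannot be ranked against one another in this assay.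

Compound 4 `OCc1cc(OCc2cc(O)ccc2O)ccc1O` differs from compound 3 in one place: hydrogen in place of chloro on an aromatic carbon. Among the measured compounds shown here, one measured step bears on this change. The same replacement, hydrogen in place of chloro on an aromatic carbon, occurs between the first two compounds, where it gave a 1.1-fold lower number from compound 1 to compound 2 (0.04 log units; within the scatter). On that precedent, no step beyond the scatter is expected in this assay for the change from compound 3 to compound 4, in either direction.

Compound 4 is therefore estimated at 5000 nM, with a range from 2500 nM to 10000 nM. This estimate means an expected step of a 1.1-fold lower number from compound 3 to compound 4 (0.03 log units; within the scatter). The estimate rests on a single precedent, and the chloro group sits on a different ring of the shared core in compound 3 than in compound 1, so the range is kept wide.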

Compound 4, half-maximal inhibitory concentration: 54700 nM
Estimate against measurement, compound 4: 11-fold (1.04 log units) below; measured number above the stated range.
By their numbers in this assay, from the lowest: compounds 3, 2 and 1 (each within the scatter of the next); then compound 4.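

In this assay, the chloro group at this place, ortho to a hydroxy group and meta to a hydroxymethyl group, proves to matter on the core of compound 3: hydrogen in its place gives a 10-fold higher number from compound 3 to compound 4 (1.01 log units; beyond the scatter). The earlier compounds shown here gave no sign of this, as the same replacement on the core of compound 1 gives a 1.1-fold lower number from compound 1 to compound 2 (0.04 log units; within the scatter). The outcome of this change therefore depends on the core that carries it and cannot be carried from one core to the other: the same change on two cores in this assay, a 1.1-fold lower number (0.04 log units; within the scatter) from compound 1 to compound 2 and a 10-fold higher number (1.01 log units; beyond the scatter) from compound 3 to compound 4, 11-fold (1.06 log units) apart, beyond the scatter of two such steps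

The compounds shown offer only chloro and hydrogen at this place, so they leave open whether the lower number of compound 3 belongs to chloro itself or would also appear with a fluoro, bromo, methyl or methoxy group on the same aromatic carbon. They also leave open which feature of the two cores separates the two outcomes, and whether replacing the hydroxymethyl group of compound 3 with a plain hydroxy group or an amine would alter the weight of the chloro group.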